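A few compounds are considered here, and "the series" means these few. Any claim that something is new, unique, unknown or untested is made for them only; others in the source may bear on it.

Three compounds sharing one core were measured in an assay on cells for positive allosteric modulation of Cystic fibrosis transmembrane conductance regulator variant F508del (Homo sapiens), with stated times of 10 min and 7 s, in the presence of a further agent that is not named here; a lower number here means that less compound is needed, a higher number that more compound is needed for the effect. Compound 1 `Cc1ccc(C(=O)Nc2sc3c(c2C(N)=O)CCOC3)s1` gives 778 nM, compound 2 `CC1Cc2c(sc(NC(=O)c3ccccc3O)c2C(N)=O)C(C)O1` gives 4 nM, and compound 3 `CC1(C)Cc2c(sc(NC(=O)c3cn[nH]c3)c2C(N)=O)C(C)(C)O1` gives 125 nM. On these numbers compound 3 stands second highest of the three: its nearest neighbour is compound 1, whose higher number lies beyond the scatter, and its furthest is compound 2, whose lower number also lies beyond the scatter. Within the data shown here, no step between a pair of measured compounds differing in only one place is available, so the three values show only where each compound sits, not what any single change is worth.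

Compound 4 `CC1(C)Cc2c(sc(NC(=O)C3(CO)CC3)c2C(N)=O)C(C)(C)O1` has not yet been measured. It differs from compound 3 in one place: 1-(hydroxymethyl)cyclopropyl in place of 1H-pyrazol-4-yl on a carbonyl carbon. Among the measured compounds shown here, nothing among the measured compounds repeats this exchange, so no step is known that would set its size. The nearest point of orientation is that compound 2, which also carries a hydroxyl, gives 4 nM, which is the lowest number of the three.

Compound 4 is therefore expected to move only moderately, if at all, toward a higher number, with the step from compound 3 estimated as a 2.0-fold higher number from compound 3 to compound 4 (0.30 log units; within the scatter). The estimated value for compound 4 in this assay is 250 nM, within a range from 50 nM to 1200 nM.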

Compound 4, half-maximal effective concentration: 15 nM
Estimate against measurement, compound 4: 17-fold (1.22 log units) above; measured number outside the range, below it.
By their numbers in this assay, from the lowest: compound 2; then compound 4; then compound 3; then compound 1.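

Among these compounds, the exchange of 1H-pyrazol-4-yl for 1-(hydroxymethyl)cyclopropyl on a carbonyl carbon gives the first measured step at this place: in this assay it amounts to an 8.3-fold lower number from compound 3 to compound 4 (0.92 log units; beyond the scatter), so what sits on this carbonyl carbon matters, and a five-membered aromatic ring is not required there for a low number. The two groups match in heavy atoms, hydrogen-bond donors and acceptors and net charge, so these counts do not separate them, and the step goes instead with the change in the groups' makeup, to a three-membered non-aromatic ring of carbon only bearing a hydroxymethyl. Nothing measured here accounts for the size of this step.

The compounds shown do not separate the share of the hydroxyl from that of the three-membered ring, which a plain 1-methylcyclopropyl group or an open chain ending in a hydroxyl on the same carbonyl carbon could address. Going by these compounds, whether the step would keep its size on the cores of compound 1 or compound 2 also stays open, since each of these differs from compound 4 in more than one place.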